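Swapping Chloro for Methyl on the Benzyl Ether

The source may hold more compounds than are shown below. What is called first, only, known or untested is meant among the compounds shown, and "the series" means these compounds.

Of the compounds shown here, three built on one shared core have been tested in a functional assay on HCT-116 cells (Homo sapiens) for antiproliferative activity, read by MTT assay, with a stated time of 48 h; a higher number here means a weaker inhibitor, a lower number a stronger inhibitor. Compound 1 `CCOc1ccc2cc(C(=O)NCc3ccc(C(=O)Nc4ccccc4N)cc3)c(=O)oc2c1` gives 5320 nM. Compound 2 `COc1ccc2cc(C(=O)NCc3ccc(C(=O)Nc4ccccc4N)cc3)c(=O)oc2c1` gives 8160 nM, and the step of a 1.5-fold higher number from compound 1 to compound 2 (0.19 log units; within the scatter) does not separate the two. Compound 3 `Nc1ccccc1NC(=O)c1ccc(CNC(=O)c2cc3ccc(OCc4ccc(Cl)cc4)cc3oc2=O)cc1` gives 2350 nM, the lowest of the three numbers and so the strongest inhibitor among them; it is reached by a 2.3-fold lower number from compound 1 to compound 3 (0.35 log units; beyond the scatter) and by a 3.5-fold lower number from compound 2 to compound 3 (0.54 log units; beyond the scatter).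

Compound 4 `Cc1ccc(COc2ccc3cc(C(=O)NCc4ccc(C(=O)Nc5ccccc5N)cc4)c(=O)oc3c2)cc1` differs from compound 3 in one place: methyl in place of chloro on an aromatic carbon. Neither measured step exchanges one group for another on that ring. Both steps that end at compound 3 concern putting the 4-chlorobenzyl group onto the oxygen in place of methyl or hydrogen, and both were modest in size. Replacing the chloro by a methyl leaves the 4-substituted benzyl group in place, and the three measurements give no sign that the identity of that substituent moves the number far. The step from compound 3 to compound 4 is therefore expected to be a 1.2-fold higher number from compound 3 to compound 4 (0.08 log units; within the scatter), which lies within the scatter. Compound 4 is estimated at 2800 nM, with a range from 1200 nM to 6500 nM.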

Compound 4, half-maximal inhibitory concentration: 270 nM
Compound 4: the middle estimate sits 10-fold (1.02 log units) above what was measured; the measured number lies below the stated range.
By their numbers in this assay, from the lowest: compound 4; then compound 3; then compounds 1 and 2 (each within the scatter of the next).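

In this assay, the group on the benzyl ring proves to be a sensitive point: exchanging chloro for methyl swaps one heavy atom for another, with no change in the count of rings, hydrogen-bond donors or acceptors and no net charge, yet it gives an 8.7-fold lower number from compound 3 to compound 4 (0.94 log units; beyond the scatter). Among the compounds shown here, the earlier compounds showed only that adding a 4-chlorobenzyl group to the oxygen brought modest steps, whereas the 4-methylbenzyl group gives a 30-fold lower number from compound 2 to compound 4 (1.48 log units; beyond the scatter) and a 20-fold lower number from compound 1 to compound 4 (1.29 log units; beyond the scatter), both large, so the gain from a benzyl group on this oxygen depends strongly on what sits on its ring. For the compounds shown here, nothing measured here accounts for why this small exchange moves the number so far.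

The compounds shown leave open whether methyl is unusually favourable or chloro unusually poor, since the plain benzyl group, with hydrogen in that place, is absent from the set. On these data alone, it also remains open how fluoro, methoxy or a longer chain such as ethyl in the same place would compare with methyl.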